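The compounds below may be only part of what the source reports. "The series", "measured", "known", "first", "only" and "open" are said of these compounds alone.

Compound 3 `CCc1cnc(N2CCC(CCCNc3ccc4c(c3)OCC4=O)CC2)nc1` is one of three compounds whose data open this account. In a functional assay on CHO-K1 cells for agonist activity at Glucose-dependent insulinotropic receptor (Mus musculus), read by HTRF and cAMP accumulation, with a stated time of 30 min (a higher number here means that more compound is needed for the effect, a lower number that less compound is needed), compound 3 gives 159 nM. Compound 1 `CC(C)(C)OC(=O)N1CCC(CCCNc2ccc3c(c2)OCS3(=O)=O)CC1` carries a different core and a different end group, and in this assay compound 1 gives 266 nM, a number that lies within the usual scatter of that of compound 3, so the two cannot be told apart on these data. Compound 2 `CC(C)(C)OC(=O)N1CCC(CCCNc2ccc3c(c2)S(=O)(=O)CC3)CC1` has no numerical result in this assay, its entry reading "not determined" (no result reported). The step now followed leads to compound 4 `COC(=O)c1cnc(N2CCC(CCCNc3ccc4c(c3)OCC4=O)CC2)nc1`, which differs from compound 3 by methoxycarbonyl in place of ethyl on an aromatic carbon. Among the compounds with values here, no pair of measured compounds shows this change, so nothing in the data says how the number will move. The change is small in size and sits at the far end of the molecule from the shared core of compound 3, and the author therefore expects no shift beyond the scatter, the expected step being a 1.3-fold higher number from compound 3 to compound 4 (0.10 log units; within the scatter). For compound 4 the estimate is 200 nM, with a range from 70 nM to 600 nM.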

Compound 4, half-maximal effective concentration: 139 nM
Compound 4: the middle estimate sits 1.4-fold (0.16 log units) above what was measured, and the stated range covers the measured number.
By their numbers in this assay, from the lowest: compounds 4, 3 and 1 (each within the scatter of the next).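

In this assay, methoxycarbonyl in place of ethyl on an aromatic carbon of the six-membered aromatic ring with 2 nitrogen gives a step within the scatter (a 1.1-fold lower number from compound 3 to compound 4 (0.06 log units; within the scatter)), so compound 3 and compound 4 cannot be told apart. Within the data shown here, this is the first pair in the account that differs in one place, and it shows that at this position, para to a large group, 4 heavy atoms with 2 hydrogen-bond acceptors can stand in place of 2 heavy atoms with none without moving the number beyond the scatter. Nothing measured here offers an explanation for this result.

As far as these compounds go, whether a carboxylic acid, an amine or a longer chain at this position would read the same remains open. Also open, from the compounds shown here alone, is whether ethyl and methoxycarbonyl would read alike on another core, such as the core of compound 1.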